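The compounds below may be only part of what the source reports. "The series", "measured", "known", "first", "only" and "open" are said of these compounds alone.

Series notes, shared core. Compound 1 `O=C(O)c1csc([C@H]2CC[C@@H]3[C@@H](/C=C/COc4ccccc4)[C@H](O)C[C@@H]3O2)n1`, compound 2 `O=C(O)c1csc([C@H]2CC[C@@H]3[C@@H](/C=C/CCCOc4ccccc4)[C@H](O)C[C@@H]3O2)n1` and compound 3 `O=C(O)c1csc([C@H]2CC[C@@H]3[C@@H](COc4ccccc4)[C@H](O)C[C@@H]3O2)n1` carry the same carboxylic acid head and bicyclic core and differ only in the side chain. In a functional assay on CHO cells for agonist activity at prostaglandin E2 receptor EP4 subtype (Homo sapiens), read by HTRF and cAMP accumulation, with a stated time of 30 min (a higher number here means that more compound is needed for the effect, a lower number that less compound is needed), compound 1 gives > 10000 nM, which is a limit of the assay and not a number. In this assay compound 2 gives > 10000 nM, again a limit. In this assay compound 3 gives > 10000 nM, also a limit. Among the measured compounds shown here, the only single-point step between measured compounds, from compound 1 to compound 2, is a step that the two limits leave unreadable from compound 1 to compound 2; its size cannot be read, because of the limit of > 10000 nM in this assay, at which 3 of the 3 values shown sit.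

Compound 4 `O=C(O)c1csc([C@H]2CC[C@@H]3[C@@H](/C=C/[C@@H](O)COc4ccccc4)[C@H](O)C[C@@H]3O2)n1` is the next member. Relative to compound 2 the change is 1-hydroxy-2-phenoxyethyl in place of 3-phenoxypropyl on a double-bonded chain carbon bound to a double-bonded chain carbon. For the measured compounds named here, no measured step bears on this change in a readable way: all three values shown sit at the same limit, so the numbers give no direction and no size for the step in this assay. The expectation for compound 4 therefore rests on the change itself rather than on a measured trend, and the estimate is set wide. The step from compound 2 to compound 4 is expected to be an at least 12-fold lower number from compound 2 to compound 4 (1.09 log units; beyond the scatter), with the value of compound 4 estimated at 800 nM and a range from 20 nM to 10000 nM.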

Compound 4, half-maximal effective concentration: 33 nM
Compound 4: the middle estimate sits 24-fold (1.38 log units) above what was measured, and the stated range covers the measured number.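

In this assay, the place on a double-bonded chain carbon bound to a double-bonded chain carbon now gives the first readable response of the series: 1-hydroxy-2-phenoxyethyl in place of 3-phenoxypropyl gives an at least 300-fold lower number from compound 2 to compound 4 (2.48 log units; beyond the scatter), and the same group in place of phenoxymethyl gives an at least 300-fold lower number from compound 1 to compound 4 (2.48 log units; beyond the scatter). In the first of these steps, the leaving and entering groups have the same count of heavy atoms and the same six-membered aromatic ring of carbon only, while the entering group adds 1 hydrogen-bond donor and 1 defined stereocentre. Both steps give only a lower bound on the true size, because each starts from a limit and not from a number: the limit of > 10000 nM in this assay, at which 3 of the 4 values shown sit.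

Going by these compounds, it remains open whether the step follows the hydroxy group itself or its defined stereocentre, and how the opposite configuration at that carbon, or a methoxy group or an amine in place of the hydroxy group, would read. Also open, on these data alone, is how a chlorine on the phenoxy ring or a longer chain between the hydroxy-bearing carbon and the phenoxy oxygen would compare with compound 4 at 33 nM.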